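The source may report more compounds than this note shows. Statements on the series, on what has been measured and on what is new or still open speak of the compounds shown alone.

Measured compounds:
compound 1, `CC(=O)N(/N=N/c1ccc(Cl)c(C(F)(F)F)c1)c1ccc(Cl)c(C(F)(F)F)c1`, gives 50600 nM in a functional assay on HeLa cells (Homo sapiens) for cytotoxicity, read by MTT assay, with a stated time of 72 h; on this read-out higher numbers stand for weaker inhibition and lower numbers for stronger inhibition
compound 2, `O=[N+]([O-])c1ccc(/N=N/Nc2ccc([N+](=O)[O-])cc2Cl)c(Cl)c1`, gives 3010 nM in this assay

Compound 2 holds the lower of the two numbers; compound 1 is the nearest, and the gap between the two is beyond the scatter. The two structures differ in more than one place, so that gap cannot be tied to any single change.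

Compound 3, `CC(=O)N(/N=N/c1ccc([N+](=O)[O-])cc1Cl)c1ccc([N+](=O)[O-])cc1Cl`, has not been measured. Against compound 2 the difference is acetyl in place of hydrogen on a nitrogen on an aromatic ring. Compound 1 also carries the acetyl group on its triazene nitrogen and shows the weaker inhibition of the two, but its aryl substituents differ as well, so its number is only a loose pointer. The step is expected to run toward a higher number, of moderate size, a 3.0-fold higher number from compound 2 to compound 3 (0.48 log units; beyond the scatter), in this assay. Compound 3 is accordingly estimated at 9000 nM, with a range from 3000 nM to 30000 nM.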

Compound 3, half-maximal inhibitory concentration: 630 nM
The estimate for compound 3 lay 14-fold (1.15 log units) above the measured number; measured number outside the range, below it.
By their numbers in this assay, from the lowest: compound 3; then compound 2; then compound 1.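

In this assay, among these compounds, acetyl in place of hydrogen on a nitrogen on an aromatic ring gives a 4.8-fold lower number from compound 2 to compound 3 (0.68 log units; beyond the scatter) on the shared core, the first step that can be tied to a single change. This position therefore accepts an acetyl group, and the hydrogen on that nitrogen is not needed for the inhibition seen in compound 2, at least with this aryl substitution. No measured property accounts for the direction or size of this step.

From the compounds shown here alone, whether the step belongs to acetyl specifically or extends to other groups on that nitrogen stays open; methyl, propanoyl or benzoyl there would separate these readings. Whether it carries over to the chloro and trifluoromethyl aryl rings of compound 1 would take the hydrogen counterpart of compound 1 to decide.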